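The source may report more compounds than this note shows. Statements on the series, on what has been measured and on what is new or still open speak of the compounds shown alone.

Measured compounds:
- Compound 1 `Cc1ccc(C2CC(=O)c3ccc(F)cc3O2)cc1`: 160 nM
- Compound 2 `Cc1ccc(C2CC(=O)c3ccc(C)cc3O2)cc1`: 500 nM

Both numbers come from an in vitro assay on BTI-TN-5B1-4 cells for inhibition of Amine oxidase [flavin-containing] B (Homo sapiens); a lower number here means a stronger inhibitor, a higher number a weaker inhibitor. Among the compounds with values here, of the two, compound 2 stands highest; the one measured step, a 3.1-fold higher number from compound 1 to compound 2 (0.49 log units; beyond the scatter), separates it from its only neighbour. Compound 3 `COc1ccc(C2CC(=O)c3ccc(C)cc3O2)cc1` is not yet measured and differs from compound 2 by methoxy in place of methyl on an aromatic carbon. Within the data shown here, the single measured step alters a different ring, so nothing measured bears directly on this change, and no step beyond the scatter is expected in this assay. Compound 3 is estimated at 500 nM, with a range of 150 nM to 1600 nM. The step so expected is no change at the digits printed from compound 2 to compound 3 (within the scatter).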

Compound 3, half-maximal inhibitory concentration: 3350 nM
Estimate against measurement, compound 3: 6.7-fold (0.83 log units) below; measured number above the stated range.
By their numbers in this assay, from the lowest: compound 1; then compound 2; then compound 3.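

Methoxy in place of methyl on this aromatic carbon, para to a large group, is not a neutral swap in this assay: it gives a 6.7-fold higher number from compound 2 to compound 3 (0.83 log units; beyond the scatter) and leaves compound 3 the weakest inhibitor of the three. Within the data shown here, the earlier step changed the other ring, so this is the first sign that the group at this position also matters. Nothing measured here offers a reason for this step.

On these data alone, it remains open whether ethyl, chloro or an amine at this position would match methyl or fall away like methoxy. Whether the same step would appear with fluoro on the other ring, as in compound 1, is also unknown.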